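The source may hold more compounds than are shown below. What is called first, only, known or untested is meant among the compounds shown, and "the series" means these compounds.

In a functional assay on NALM-6 cells (Homo sapiens) for cytotoxicity, with a stated time of 72 h (on this read-out higher numbers stand for an effect only at larger amounts of compound and lower numbers for an effect already at smaller amounts), compound 1 (`C=C[C@@](C)(/C=C/c1ccc(O)c(/C=C(\C)C(=O)OCC)c1)CCC=C(C)C`) gives > 7500 nM, which is a limit of the assay. Among the compounds with values here, compound 2 (`CCOC(=O)/C(C)=C/c1cc(/C=C/[C@](C)(/C=C/c2ccc(OC)cc2)CCC=C(C)C)ccc1O`) gives > 43400 nM, also a limit, so it has no numerical value, and neither does the only other compound measured. Compound 3 (`COc1ccc(/C=C/[C@@](C)(/C=C/c2ccc(O)c(/C=C/C(C)=O)c2)CCC=C(C)C)cc1`) differs from compound 2 at one place: 2-acetylethenyl in place of 2-(ethoxycarbonyl)prop-1-en-1-yl on an aromatic carbon. Within the data shown here, the only measured step, a step that the two limits leave unreadable from compound 1 to compound 2, concerns a different place and its size cannot be read, so it gives little guidance. A modest shift towards smaller amounts is expected, estimated as an at least 1.7-fold lower number from compound 2 to compound 3 (0.23 log units; that floor lies within the scatter). Compound 3 is estimated at 25000 nM, with an expected range of 6000 nM to 80000 nM.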

Compound 3, half-maximal effective concentration: > 43400 nM
Compound 3 gave a limit, no number; the forecaster's own chance of this, stated with the estimate: 55%; middle value at least 1.7-fold (0.23 log units) from the limit.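

No step can be read from compound 2 to compound 3, because both give only a limit: the limit of > 43400 nM in this assay, at which 2 of the 3 values shown sit.

The compounds shown leave open how large an effect either change has in this assay, as none of the three has a numerical value.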